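The compounds below may be only part of what the source reports. "The series", "measured", "known", "first", "only" and "open" are said of these compounds alone.

Compounds measured so far:
Compound 1 `CC(C)c1cc(-c2n[nH]c(=O)n2-c2cccc(C(=O)NCCCCCCC(=O)NO)c2)c(O)cc1O`; in a functional assay on HEL cells (Homo sapiens) for inhibition (on this read-out higher numbers stand for weaker inhibition and lower numbers for stronger inhibition), compound 1 gives 4600 nM.
Compound 2 `CC(C)c1cc(-c2n[nH]c(=O)n2-c2ccc(C(=O)NCCCCCCC(=O)NO)cc2)c(O)cc1O`; in this assay compound 2 gives 4600 nM.
Compound 3 `CC(C)c1cc(-c2n[nH]c(=O)n2-c2cccc(C(=O)NCCCCC(=O)NO)c2)c(O)cc1O`; in this assay compound 3 gives 4600 nM.

Compound 2 stands level with compounds 1 and 3 at the digits shown: its value in this assay sits within the scatter of both, so no order among the three can be read from these numbers.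

Compound 4 `CC(C)c1cc(-c2n[nH]c(=O)n2-c2ccc(C(=O)NCCCCCC(=O)NO)cc2)c(O)cc1O` has not yet been measured in this assay. It differs from compound 2 in one place: hydroxycarbamoyl in place of (hydroxycarbamoyl)methyl on a saturated chain carbon, five bonds along the chain from an amide-type nitrogen.

Within the data shown here, only one measured step bears on this change. It is no change at the digits printed from compound 1 to compound 3 (within the scatter), where the same chain on the core of compound 1 was shortened by a larger amount than here and the read-out did not move beyond the scatter. Compound 4 shortens the chain by less, on the core of compound 2. The expectation is therefore a step of no size beyond the scatter in this assay, in neither direction.

Compound 4 is estimated to give 4600 nM in this assay, with an expected range from 2300 nM to 9200 nM. The estimated step is no change at the digits printed from compound 2 to compound 4 (within the scatter).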

Compound 4, half-maximal inhibitory concentration: 4600 nM
Beside the measured number, compound 4's estimate shows no gap at the digits printed; the measured number falls inside the stated range.
By their numbers in this assay, from the lowest: compounds 1, 2, 3 and 4 (each within the scatter of the next).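

In this assay there is no change at the digits printed from compound 2 to compound 4 (within the scatter), so shortening the chain at this saturated carbon, five bonds along the chain from an amide-type nitrogen, now has a measured outcome on the core of compound 2 as well. Together with no change at the digits printed from compound 1 to compound 3 (within the scatter) on the core of compound 1, this gives two shortenings on two cores, and neither moves the read-out beyond the scatter. No supporting data are available to explain why the read-out stays level.

From the compounds shown here alone, it remains open whether a longer chain, or a much shorter one, would shift the read-out at all. Also unresolved is whether a carboxylic acid or a primary amide in place of the hydroxycarbamoyl end would leave the value where it stands.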